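From a methoxyphenyl to a bromophenyl on the carbonyl

The source may report more compounds than this note shows. Statements on the series, on what has been measured and on what is new or still open speak of the compounds shown alone.

Measured in a functional assay on MCF7 cells (Homo sapiens) for inhibition, read by MTT assay, with a stated time of 24 h (on this read-out higher numbers stand for weaker inhibition of growth and lower numbers for stronger inhibition of growth), so far:
- compound 1 (`Cn1cc(-c2nc3ccccc3n2C(=O)c2ccccc2Br)c2ccccc21`) gives 70100 nM
- compound 2 (`COc1ccccc1C(=O)n1c(-c2cn(C)c3ccc(Br)cc23)nc2ccccc21`) gives 36200 nM
- compound 3 (`COc1cccc(C(=O)n2c(-c3cn(C)c4ccc(Br)cc34)nc3ccccc32)c1`) gives 18200 nM

Compound 3 lies within the usual scatter of compound 2, while compound 1 stands beyond the scatter at a higher number. The next compound to be tested is compound 4 (`Cn1cc(-c2nc3ccccc3n2C(=O)c2ccccc2Br)c2cc(Br)ccc21`), which has 2-bromophenyl in place of 3-methoxyphenyl on a carbonyl carbon. It keeps the core of compound 2 and compound 3. Going by the values given here, the one measured step at this carbonyl carbon, with 3-methoxyphenyl in place of 2-methoxyphenyl, is a 2.0-fold lower number from compound 2 to compound 3 (0.30 log units; within the scatter) and so shows little. The 2-bromophenyl group also sits on the carbonyl carbon of compound 1 with 70100 nM in this assay on a core not shared with compound 4, so it is only a loose guide. Its high number still tips the expectation slightly upward. The expected change is a 1.8-fold higher number from compound 3 to compound 4 (0.25 log units; within the scatter) in this assay and no larger step is expected. The estimated value for compound 4 is 32000 nM with an expected range (13000 nM to 75000 nM).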

Compound 4, concentration for 50% growth inhibition: 73600 nM
The estimate for compound 4 lay 2.3-fold (0.36 log units) below the measured number; the measured number falls inside the stated range.
By their numbers in this assay, from the lowest: compounds 3, 2, 1 and 4 (each within the scatter of the next, the first and the last beyond it).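

In this assay, going by these compounds alone, 2-bromophenyl in place of 3-methoxyphenyl on the carbonyl carbon gives a 4.0-fold higher number from compound 3 to compound 4 (0.61 log units; beyond the scatter) and is the first change at this position to lie beyond the scatter. Bromo in place of methoxy gives a 2.0-fold higher number from compound 2 to compound 4 (0.31 log units; beyond the scatter) as well, so on this core the 2-bromophenyl compound stands above both methoxyphenyl compounds, which themselves lie within the scatter of each other. Bromo in place of hydrogen on an aromatic carbon gives a 1.0-fold higher number from compound 1 to compound 4 (0.02 log units; within the scatter) and so makes no readable difference while 2-bromophenyl sits on the carbonyl carbon.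

Nothing available here explains why the numbers differ. On these data alone, it stays open how a phenyl carrying an amine or a carboxylic acid on this carbonyl carbon would compare with the 3-methoxyphenyl of compound 3.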